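Swapping Chloro for Amino: an Expected Weakening

The compounds below may be only part of what the source reports. "The series", "measured", "known", "first", "only" and "open" are said of these compounds alone.

Measured so far:
Compound 1, `Nc1nc(Cl)c2ncn(Cc3ccc(CCl)cc3)c2n1`, gives 6920 nM in a functional assay on T47D cells (Homo sapiens) for cytotoxicity, read by sulforhodamine B assay, with a stated time of 48 h; a lower number here means a stronger inhibitor of growth, a higher number a weaker inhibitor of growth.
Compound 2, `ClCc1cccc(Cn2cnc3c(Cl)nc(Cl)nc32)c1`, gives 1950 nM in this assay.
Compound 3, `ClCc1ccc(Cn2cnc3c(Cl)nc(Cl)nc32)cc1`, gives 1380 nM in this assay.

Compounds 2 and 3 are built from the same atoms joined differently; the difference between the two cores is not broken down here, and their two values lie within the usual scatter of each other. Compound 1 differs from compound 3 in one place only, (amino in place of chloro on an aromatic carbon), and that single change gave a 5.0-fold higher number from compound 3 to compound 1 (0.70 log units; beyond the scatter), so compound 1 is the weaker growth inhibitor of the two.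

Compound 4, `Nc1nc(Cl)c2ncn(Cc3cccc(CCl)c3)c2n1`, has not yet been measured. It differs from compound 2 by amino in place of chloro on an aromatic carbon, the same change at the same place as before. For the measured compounds named here, because the one measured example of this change gave a 5.0-fold higher number from compound 3 to compound 1 (0.70 log units; beyond the scatter), the expected step is a 4.6-fold higher number from compound 2 to compound 4 (0.66 log units; beyond the scatter), resting on that single precedent alone. Compound 4 is therefore estimated to give about 9000 nM in this assay, with a plausible range from 4000 nM to 20000 nM.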

Compound 4, concentration for 50% growth inhibition: 6020 nM
The estimate for compound 4 lay 1.5-fold (0.17 log units) above the measured number, within the range that was stated.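

In this assay, amino in place of chloro on the aromatic carbon again weakened growth inhibition, with a 3.1-fold higher number from compound 2 to compound 4 (0.49 log units; beyond the scatter). Set side by side, the two examples of this change point the same way and cannot be told apart in size: the same change on two cores in this assay, a 5.0-fold higher number (0.70 log units; beyond the scatter) from compound 3 to compound 1 and a 3.1-fold higher number (0.49 log units; beyond the scatter) from compound 2 to compound 4, 1.6-fold (0.21 log units) apart, within the scatter of two such steps. This shows that the change carried over from one core to the other in this series, but two pairs are a small sample, so they do not show that it would carry over to any further core, nor do they explain why the amino compounds are the weaker inhibitors.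

The compounds shown leave open whether a different group on that same aromatic carbon, such as methylamino or methoxy, would keep the growth inhibition of the chloro compounds or weaken it as amino does. On these data alone, whether the step would hold in other cell lines also remains open.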